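Furan for Thiophene on a Saturated Ring Carbon

The source may report more compounds than this note shows. Statements on the series, on what has been measured and on what is new or still open speak of the compounds shown alone.

Two compounds of a shared core have been measured in a functional assay on A549 cells (Homo sapiens) for cytotoxicity, read by sulforhodamine B assay, with a stated time of 72 h; on this read-out lower numbers stand for stronger inhibition and higher numbers for weaker inhibition:

compound 1, `O=C1CC(c2ccccc2)c2c(sc(-c3ccc(Cl)cc3)c2-c2ccc(Cl)cc2)N1`, giving 17200 nM
compound 2, `O=C1CC(c2cccs2)c2c(sc(-c3ccc(Cl)cc3)c2-c2ccc(Cl)cc2)N1`, giving 20200 nM

Compound 2 gives the highest of the two numbers, and its nearest neighbour is compound 1; the two values lie within the scatter of each other, so no order between them can be read.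

Compound 3, `O=C1CC(c2ccco2)c2c(sc(-c3ccc(Cl)cc3)c2-c2ccc(Cl)cc2)N1`, has not yet been measured. It differs from compound 2 by furan-2-yl in place of thiophen-2-yl on a saturated ring carbon. For the measured compounds named here, the only measured step that bears on this position is a 1.2-fold higher number from compound 1 to compound 2 (0.07 log units; within the scatter), a change at the same saturated ring carbon that left the number where it was. On that basis the exchange of one five-membered aromatic ring for another at this position is expected to give no step beyond the scatter in this assay, which is to say a 1.0-fold lower number from compound 2 to compound 3 (0.00 log units; within the scatter). Compound 3 is therefore estimated at 20000 nM, with a range from 8000 nM to 50000 nM.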

Compound 3, half-maximal inhibitory concentration: 25400 nM
Compound 3: the middle estimate sits 1.3-fold (0.10 log units) below what was measured, and the stated range covers the measured number.
By their numbers in this assay, from the lowest: compounds 1, 2 and 3 (each within the scatter of the next).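

Furan-2-yl in place of thiophen-2-yl on the saturated ring carbon gives a 1.3-fold higher number from compound 2 to compound 3 (0.10 log units; within the scatter) in this assay, and furan-2-yl in place of phenyl gives a 1.5-fold higher number from compound 1 to compound 3 (0.17 log units; within the scatter). Phenyl, thiophen-2-yl and furan-2-yl at this carbon thus all lie within the scatter of one another, and exchanging the sulfur of the five-membered aromatic ring for oxygen leaves no readable step, just as the earlier exchange of phenyl for thiophen-2-yl did. Nothing available explains why these numbers stay together.

The compounds shown leave open whether a non-aromatic group at this carbon, such as an amine, a carboxylic acid or a longer alkyl chain, would move the number beyond the scatter. They also leave open what changes elsewhere on the shared core would do.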